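The compounds below may be only part of what the source reports. "The series", "measured", "known", "first", "only" and "open" are said of these compounds alone.

Measured compounds:
Compound 1 `COc1cc(/C=C/C(=O)Nc2cc3c(Nc4ccc(F)c(Cl)c4)ncnc3cc2O[C@H]2CCOC2)cc(OC)c1O` gives 26500 nM in a functional assay on PC-3 cells (Homo sapiens) for cytotoxicity, read by MTT assay, with a stated time of 72 h; a higher number here means a weaker inhibitor, a lower number a stronger inhibitor.
Compound 2 `COc1cc2ncnc(Nc3ccc(F)c(Cl)c3)c2cc1NC(=O)/C=C/c1ccc(C#N)cc1` is reported in this assay as "not active" (no number reported).

Compound 1 therefore holds the only number shown; compound 2 offers no number at all. Compound 3 `O=C(/C=C/c1ccc(Br)cc1)Nc1cc2c(Nc3ccc(F)c(Cl)c3)ncnc2cc1O[C@H]1CCOC1` has not yet been measured in this assay. It differs from compound 1 by 4-bromophenyl in place of 4-hydroxy-3,5-dimethoxyphenyl on a double-bonded chain carbon bound to a double-bonded chain carbon. Going by the values given here, no measured pair covers this change, so the direction rests on expectation alone: the expected step is a 1.5-fold higher number from compound 1 to compound 3 (0.18 log units; within the scatter), leaning towards weaker inhibition, though it may stay within the scatter. Compound 3 is estimated in this assay at 40000 nM, with a range from 15000 nM to 110000 nM.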

Compound 3, half-maximal inhibitory concentration: 28200 nM
Estimate against measurement, compound 3: 1.4-fold (0.15 log units) above; measured number inside the range.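

Going by these compounds alone, at this position, 4-bromophenyl in place of 4-hydroxy-3,5-dimethoxyphenyl gives the first measured step in this assay, a 1.1-fold higher number from compound 1 to compound 3 (0.03 log units; within the scatter). The entering group has no hydrogen-bond donors or acceptors, whereas the leaving group has both, yet this exchange leaves the two compounds indistinguishable in this read-out. No measured evidence bears on the reason for this result. On these data alone, whether an amine or a carboxylic acid on this phenyl ring would shift the number remains open. So does whether any group at this position can produce a step beyond the scatter.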